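Working notes: 4-methoxyphenyl variant of compound 3

The source may report more compounds than this note shows. Statements on the series, on what has been measured and on what is new or still open speak of the compounds shown alone.

- compound 1 `COc1ccc(/C=C/C(=O)Nc2cc3c(Nc4ccc(F)c(Cl)c4)ncnc3cc2O[C@H]2CCOC2)c(OC)c1`: 2760 nM
- compound 2 `COc1ccc(/C=C/C(=O)Nc2cc3c(Nc4ccc(F)c(Cl)c4)ncnc3cc2OC)cc1`: "not active" (no number reported)
- compound 3 `COc1cc(/C=C/C(=O)Nc2cc3c(Nc4ccc(F)c(Cl)c4)ncnc3cc2O[C@H]2CCOC2)cc(OC)c1O`: 26500 nM

In a functional assay on PC-3 cells (Homo sapiens) for cytotoxicity, read by MTT assay, with a stated time of 72 h (a higher number here means a weaker inhibitor, a lower number a stronger inhibitor), compound 3 holds the higher of the two numbers, at 26500 nM. Compound 4 `COc1ccc(/C=C/C(=O)Nc2cc3c(Nc4ccc(F)c(Cl)c4)ncnc3cc2O[C@H]2CCOC2)cc1` is not yet measured. It follows from compound 3 by 4-methoxyphenyl in place of 4-hydroxy-3,5-dimethoxyphenyl on a double-bonded chain carbon bound to a double-bonded chain carbon, with 4-methoxyphenyl in place of 4-hydroxy-3,5-dimethoxyphenyl.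

For the measured compounds named here, one measured step bears directly on this place: a 9.6-fold higher number from compound 1 to compound 3 (0.98 log units; beyond the scatter), which came with the entry of 4-hydroxy-3,5-dimethoxyphenyl in place of 2,4-dimethoxyphenyl. Compound 4 gives up that same group, so a move back toward the number of compound 1 is expected. Caution comes from compound 2, which also carries 4-methoxyphenyl and gave "not active" (no number reported), without a number.

The expected step is a 3.3-fold lower number from compound 3 to compound 4 (0.52 log units; beyond the scatter), toward a lower number in this assay and smaller than the measured one. Compound 4 is estimated at 8000 nM, with an expected range of 2000 nM to 30000 nM.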

Compound 4, half-maximal inhibitory concentration: 2240 nM
For compound 4 the middle estimate is 3.6-fold (0.55 log units) above the measured one, and the stated range covers the measured number.
By their numbers in this assay, from the lowest: compounds 4 and 1 (each within the scatter of the next); then compound 3.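

In this assay, 4-methoxyphenyl in place of 4-hydroxy-3,5-dimethoxyphenyl on a double-bonded chain carbon bound to a double-bonded chain carbon gives a 12-fold lower number from compound 3 to compound 4 (1.07 log units; beyond the scatter) as a large step, so the weak number of compound 3 is tied to what that group carries and is not simply the absence of the 2,4-dimethoxyphenyl group of compound 1. Hydrogen in place of methoxy on an aromatic carbon gives a 1.2-fold lower number from compound 1 to compound 4 (0.09 log units; within the scatter) and leaves the two compounds within the scatter, so the extra methoxy of compound 1 is not needed at this place in this assay. Nothing measured on these compounds accounts for the large step.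

The hydroxy and the two methoxy groups leave together in the step to compound 4, so their separate shares remain unresolved. A 4-hydroxyphenyl or 4-aminophenyl group at this place would separate the effect of the hydroxy from that of the methoxy groups and test a different substituent there.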